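Swapping an Ethynyl for a Methoxy on a Weak Scaffold

This account rests on a few compounds, and the source may have more. Where it says the series, first, only, none or still open, it means among the compounds named here.

Compound 1, `C#Cc1cccc(Nc2ncnc3oc(C)c(C(=O)OCC)c23)c1`, was tested in a functional assay on MCF7 cells (Homo sapiens) for cytotoxicity, read by MTT assay, with a stated time of 72 h; on this read-out higher numbers stand for weaker inhibition and lower numbers for stronger inhibition. In this assay compound 1 gives > 1000000 nM, which is a limit of the assay rather than a measured number. Among the measured compounds shown here, that limit is the only information on where compound 1 stands: the limit of > 1000000 nM in this assay, at which 1 of the 2 values shown sits. For the measured compounds named here, a second compound on the same shared core, compound 2, `Cc1oc2ncnc(Nc3cccc(Br)c3)c2c1CO`, differs from compound 1 in more than one place, and in this assay compound 2 gives 11000 nM; no single-change step connects the two, so their values only show that one member of this core reaches a measurable number while the other does not.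

Compound 3, `CCOC(=O)c1c(C)oc2ncnc(Nc3cccc(OC)c3)c12`, has not yet been tested. Its difference from compound 1 is small: methoxy in place of ethynyl on an aromatic carbon The rest of the molecule, including the ethyl ester on the shared core, is kept. Because compound 1 sits at the limit of > 1000000 nM in this assay, at which 1 of the 2 values shown sits, no measured step is available to size this change, and the methoxy group has no precedent among the compounds shown. The expectation is therefore that compound 3 stays weak, with a fair chance that this assay again reports only a limit. The step that this estimate means is expected to be an at least 5.0-fold lower number from compound 1 to compound 3 (0.69 log units; beyond the scatter). Compound 3 is estimated at 200000 nM, within an expected range from 20000 nM to 1000000 nM.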

Compound 3, half-maximal inhibitory concentration: > 1000000 nM
Compound 3 was reported as a limit; the forecaster's own chance of this, stated with the estimate: 50%; middle value at least 5.0-fold (0.69 log units) away from the limit.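

In this assay compound 3 gives > 1000000 nM, which is a limit of the assay and not a measured number. Compound 1 is also reported only as a limit, so no step between compound 1 and compound 3 can be read: the limit of > 1000000 nM in this assay, at which 2 of the 3 values shown sit.

The compounds shown leave open whether putting methoxy in place of ethynyl changes the cytotoxicity at all.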